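Benzyloxycarbonyl for methyl, repeated on a chloro analogue

This account rests on a few compounds, and the source may have more. Where it says the series, first, only, none or still open, it means among the compounds named here.

Measured so far:
compound 1 `Cc1ccc2[nH]c(-c3cn(-c4ccccc4)nc3-c3ccccc3)nc2c1` — in a functional assay on A549 cells (Homo sapiens) for antiproliferative activity, read by MTT assay, with a stated time of 48 h (a lower number here means a stronger inhibitor, a higher number a weaker inhibitor), compound 1 gives 3610 nM
compound 2 `O=C(OCc1ccccc1)c1ccc2[nH]c(-c3cn(-c4ccccc4)nc3-c3ccccc3)nc2c1` — compound 2 gives 19300 nM
compound 3 `Cc1ccc2[nH]c(-c3cn(-c4ccccc4)nc3-c3ccc(Cl)cc3)nc2c1` — compound 3 gives 4640 nM

Compound 2 differs from compound 1 by benzyloxycarbonyl in place of methyl on an aromatic carbon, and this change gave a 5.3-fold higher number from compound 1 to compound 2 (0.73 log units; beyond the scatter). Compound 3 differs from compound 1 by chloro in place of hydrogen on an aromatic carbon, a change that gave a 1.3-fold higher number from compound 1 to compound 3 (0.11 log units; within the scatter). Compound 4 `O=C(OCc1ccccc1)c1ccc2[nH]c(-c3cn(-c4ccccc4)nc3-c3ccc(Cl)cc3)nc2c1` has not yet been measured in this assay; it differs from compound 3 by benzyloxycarbonyl in place of methyl on an aromatic carbon, the same change, at the same place, as that from compound 1 to compound 2. For the measured compounds named here, the only guide is that earlier step. Compound 4 is therefore expected to show a 5.2-fold higher number from compound 3 to compound 4 (0.71 log units; beyond the scatter), a step of about the same size as the earlier one because a 5.3-fold higher number from compound 1 to compound 2 (0.73 log units; beyond the scatter) came from a change that reads alike. The estimate for compound 4 is 24000 nM, with a likely range from 9000 nM to 65000 nM.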

Compound 4, half-maximal inhibitory concentration: 7730 nM
The estimate for compound 4 lay 3.1-fold (0.49 log units) above the measured number, and the stated range ends above it.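

In this assay, benzyloxycarbonyl in place of methyl did not carry over at its earlier size to the chloro analogue, giving a 1.7-fold higher number from compound 3 to compound 4 (0.22 log units; within the scatter), and the two steps differ: the same change on two cores in this assay, a 5.3-fold higher number (0.73 log units; beyond the scatter) from compound 1 to compound 2 and a 1.7-fold higher number (0.22 log units; within the scatter) from compound 3 to compound 4, 3.2-fold (0.51 log units) apart, beyond the scatter of two such steps. Read the other way, chloro in place of hydrogen gave a 2.5-fold lower number from compound 2 to compound 4 (0.40 log units; beyond the scatter), and this step also depends on the core: the same change on two cores in this assay, a 1.3-fold higher number (0.11 log units; within the scatter) from compound 1 to compound 3 and a 2.5-fold lower number (0.40 log units; beyond the scatter) from compound 2 to compound 4, 3.2-fold (0.51 log units) apart, beyond the scatter of two such steps. The two changes therefore do not add independently across these four compounds, but this single set of four does not show why the steps differ or whether other cores would behave the same way.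

Going by these compounds, it remains open whether methoxycarbonyl, a carboxylic acid or an amide in place of benzyloxycarbonyl would show the same dependence on the core. On these data alone, it is also open whether fluoro or methoxy in place of chloro would do so.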